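Swapping the ring on the ketone: tetrazole replaces thiadiazole

A few compounds are considered here, and "the series" means these few. Any claim that something is new, unique, unknown or untested is made for them only; others in the source may bear on it.

Going by the values given here, three close relatives share a long chain ending in a phenyl group, joined through a carbonyl to a small five-membered aromatic ring; only that ring differs. In an assay for inhibition of Fatty-acid amide hydrolase 1 (Rattus norvegicus), at pH 9.0 (on this read-out lower numbers stand for stronger inhibition and higher numbers for weaker inhibition), compound 1 `O=C(CCCCCCc1ccccc1)c1ncno1` gives 1 nM, compound 2 `O=C(CCCCCCc1ccccc1)c1ncon1` gives 7 nM, and compound 3 `O=C(CCCCCCc1ccccc1)c1nncs1` gives 1.4 nM. Compound 3 thus holds the second-highest of the three numbers: its nearest neighbour is compound 1, and the step of a 1.4-fold higher number from compound 1 to compound 3 (0.15 log units; within the scatter); its furthest is compound 2, where a 5.0-fold lower number from compound 2 to compound 3 (0.70 log units; beyond the scatter). The first two rings themselves differ by a 7.0-fold higher number from compound 1 to compound 2 (0.85 log units; beyond the scatter).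

Compound 4 `O=C(CCCCCCc1ccccc1)c1nnn[nH]1` continues the series with 1H-tetrazol-5-yl in place of 1,3,4-thiadiazol-2-yl on a carbonyl carbon. Each earlier ring swap on this carbonyl carbon moved this assay by a modest amount at most, so a modest shift, leaning toward a higher number, is expected for the step of an 11-fold higher number from compound 3 to compound 4 (1.03 log units; beyond the scatter). Compound 4 is therefore estimated at 15 nM, between 3 nM and 100 nM.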

Compound 4, inhibition constant: > 1000 nM
Compound 4: only a limit was reported; the forecaster's own chance of this, stated with the estimate: 3%; at least 66-fold (1.82 log units) between middle value and limit.
By their numbers in this assay, from the lowest: compounds 1 and 3 (each within the scatter of the next); then compound 2. At a limit, above all of these: compound 4.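

In this assay the value for compound 4 is a limit, not a number: the limit of > 1000 nM in this assay, at which 1 of the 4 values shown sits. The earlier ring swaps on this carbonyl carbon gave modest steps at most, whereas 1H-tetrazol-5-yl gives an at least 710-fold higher number from compound 3 to compound 4 (2.85 log units; beyond the scatter), an at least 140-fold higher number from compound 2 to compound 4 (2.15 log units; beyond the scatter) and an at least 1000-fold higher number from compound 1 to compound 4 (3.00 log units; beyond the scatter). So this position does not treat all five-membered aromatic rings alike, even though 1H-tetrazol-5-yl has the same number of heavy atoms as 1,3,4-thiadiazol-2-yl and, unlike it, carries a hydrogen-bond donor.

With a single tetrazole, the compounds shown cannot separate the role of that donor from the role of the ring's other changes, and no cause for the loss can be assigned. From the compounds shown here alone, it also remains open how a methyl group on the tetrazole nitrogen in place of that hydrogen would read in this assay.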